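A Chloro Added to Compound 1

The compounds below may be only part of what the source reports. "The series", "measured", "known", "first", "only" and "open" are said of these compounds alone.

Measured so far in a functional assay on MDA-MB-231 cells (Homo sapiens) for antiproliferative activity, read by WST assay, with a stated time of 72 h; on this read-out higher numbers stand for weaker inhibition and lower numbers for stronger inhibition:
Compound 1 `COC(=O)/C=C/c1ccc(NCc2ccccc2O)cc1`: 31700 nM
Compound 2 `COC(=O)/C=C/c1ccc(NCc2ccc(O)c(O)c2)cc1`: 36600 nM

Among the measured compounds shown here, these are the only two measurements available, and they lie within the usual scatter of repeated measurements of each other. Compound 1 therefore cannot be ranked against compound 2, and the two simply mark the same level of activity.

The next compound to be tested is compound 3 `COC(=O)/C=C/c1ccc(NCc2cc(Cl)ccc2O)cc1`. It keeps the core of compound 1 and carries one change: chloro in place of hydrogen on an aromatic carbon. The chloro sits para to a hydroxy group.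

For the measured compounds named here, no pair of measured compounds tests a chloro, so the data offer no direct guide to the size of this step. A single added atom is expected to shift the number only modestly in this assay, and a small move towards stronger inhibition is the tentative expectation. The expected change is a 1.6-fold lower number from compound 1 to compound 3 (0.20 log units; within the scatter), which may not clear the scatter.

For compound 3 the estimated value is 20000 nM, with an expected range from 8000 nM to 45000 nM.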

Compound 3, half-maximal inhibitory concentration: 86400 nM
Compound 3: the middle estimate sits 4.3-fold (0.64 log units) below what was measured; the measured number lies above the stated range.
By their numbers in this assay, from the lowest: compounds 1 and 2 (each within the scatter of the next); then compound 3.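

Replacing hydrogen with chloro on this aromatic carbon, para to a hydroxy group, gives a 2.7-fold higher number from compound 1 to compound 3 (0.44 log units; beyond the scatter) in this assay. This position therefore does not tolerate every change: a single added heavy atom is enough to weaken inhibition by a step that lies beyond the scatter, and it is the first step shown between two compounds that differ in one place. Among the compounds shown here, nothing measured so far gives a reason for this rise in the number.

From the compounds shown here alone, it remains open whether the weaker inhibition is specific to chloro or would follow any group on this carbon, a question that a fluoro, a methyl or a methoxy at the same place could begin to answer. Going by these compounds, it is also open whether chloro on a different carbon of the same ring would give a step of similar size and direction, or whether this one position is particularly sensitive to change.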